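Replacing a furan amide with a chlorophenyl sulfonamide

A few compounds are considered here, and "the series" means these few. Any claim that something is new, unique, unknown or untested is made for them only; others in the source may bear on it.

Measured so far in a functional assay on A549 cells (Homo sapiens) for antiproliferative activity, read by MTT assay, with a stated time of 72 h; a lower number here means a stronger inhibitor, a higher number a weaker inhibitor:
- compound 1, `CN(C(=O)c1ccc(Cl)cc1)c1ccc2[nH]c(-c3n[nH]c4ccccc34)cc2n1`: 2220 nM
- compound 2, `COc1ccc(C(=O)N(C)c2ccc3[nH]c(-c4n[nH]c5ccccc45)cc3n2)cc1`: 14600 nM
- compound 3, `CN(C(=O)c1ccco1)c1ccc2[nH]c(-c3n[nH]c4ccccc34)cc2n1`: 15500 nM

Compound 3 gives the highest number of the three in this assay, though compound 2 is within scatter of it (a 1.1-fold higher number from compound 2 to compound 3 (0.03 log units; within the scatter)). Compound 4, `CN(c1ccc2[nH]c(-c3n[nH]c4ccccc34)cc2n1)S(=O)(=O)c1ccc(Cl)cc1`, has not been measured; it carries (4-chlorophenyl)sulfonyl in place of (furan-2-yl)carbonyl on a nitrogen on an aromatic ring. Going by the values given here, one measured step bears on this: a 7.0-fold higher number from compound 1 to compound 3 (0.84 log units; beyond the scatter), which suggests that bringing the 4-chlorophenyl group back should lower the number. Among the compounds with values here, the carbonyl-to-sulfonyl exchange has no measured counterpart, so the size is uncertain. The expected step is a 3.9-fold lower number from compound 3 to compound 4 (0.59 log units; beyond the scatter). Compound 4 is therefore estimated at 4000 nM in this assay, with a range from 1000 nM to 20000 nM.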

Compound 4, half-maximal inhibitory concentration: 18200 nM
Compound 4: middle estimate off by 4.6-fold (0.66 log units), on the low side, and the stated range covers the measured number.
By their numbers in this assay, from the lowest: compound 1; then compounds 2, 3 and 4 (each within the scatter of the next).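

Moving from carbonyl to sulfonyl while keeping the 4-chlorophenyl group gives an 8.2-fold higher number from compound 1 to compound 4 (0.91 log units; beyond the scatter), so the lower number of compound 1 does not survive this exchange of linking group. The sulfonamide also shows no separation from the two weaker amides, with a 1.2-fold higher number from compound 3 to compound 4 (0.07 log units; within the scatter) and a 1.2-fold higher number from compound 2 to compound 4 (0.10 log units; within the scatter) as the steps. Nothing measured here explains this loss.

Still open, from the compounds shown here alone, is whether an amine or a carboxylic acid in place of the chloro would lower the number on the carbonyl series. Whether any other group on the sulfonyl could do so is also unanswered.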